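A few compounds are considered here, and "the series" means these few. Any claim that something is new, unique, unknown or untested is made for them only; others in the source may bear on it.

Measured compounds:
compound 1, `Cc1ccc(CSc2nc(C3CCCCC3)c(C#N)c(=O)[nH]2)cc1`, 38700 nM
compound 2, `Cc1ccc(C)c(CSc2nc(C3CCN(C)CC3)c(C#N)c(=O)[nH]2)c1`, 127000 nM
compound 3, `N#Cc1c(C2CCCCC2)nc(SCC(=O)Nc2ccccc2)[nH]c1=O`, a limit only

In an assay on isolated protein for inhibition of Rap guanine nucleotide exchange factor 4 (Homo sapiens), read by fluorescence and cAMP accumulation (a higher number here means a weaker inhibitor, a lower number a stronger inhibitor), compound 1 gives 38700 nM. Compound 2 gives 127000 nM in this assay. For compound 3 this assay reports only a limit, > 300000 nM, so compound 3 stands at the weak end of the three without a definite number; this is the same threshold described by the limit of > 300000 nM in this assay, at which 1 of the 3 values shown sits. Nothing in these values separates compound 3 from the pair of measured numbers beyond the fact of the limit itself.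

Compound 4, `Cc1ccc(NC(=O)CSc2nc(C3CCCCC3)c(C#N)c(=O)[nH]2)cc1`, differs from compound 3 by methyl in place of hydrogen on an aromatic carbon. Among the measured compounds shown here, no pair of measured compounds here shows the effect of this change, so the expected size of the step rests only on the small scale of the change itself. Compound 4 is estimated to sit near the same limit as compound 3, with the step of a number no higher from compound 3 to compound 4 (the limit leaves the size open) expected to stay within the scatter of this assay. The estimate for compound 4 is 300000 nM, spanning 100000 nM to 1000000 nM, with a limit rather than a number being the more likely outcome.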

Compound 4, half-maximal inhibitory concentration: > 300000 nM
Compound 4: only a limit was reported; the forecaster's own chance of this, stated with the estimate: 65%; the middle value lies on the limit itself.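

In this assay compound 4 gives only a limit, > 300000 nM. Compound 3 also stands at a limit, so no step can be read between compound 3 and compound 4. The compounds shown leave open what methyl in place of hydrogen does to inhibition: the limit of > 300000 nM in this assay, at which 2 of the 4 values shown sit.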